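From methoxycarbonyl to cyano at the assay limit

The source may hold more compounds than are shown below. What is called first, only, known or untested is meant among the compounds shown, and "the series" means these compounds.

Compound 1 `CCC(=O)N(c1ccc(Cl)cc1)C1CCCC1N(C)C`: > 50 mg/kg
Compound 2 `CCC(=O)N(c1ccc(F)cc1)C1CCCC1N(C)C`: > 50 mg/kg
Compound 3 `CCC(=O)N(c1ccc(C(=O)OC)cc1)C1CCCC1N(C)C`: > 50 mg/kg

Each of these three values is a limit and not a number. All were obtained in a functional assay on the whole organism for positive allosteric modulation, with Mus musculus as the target; a lower number here means that less compound is needed, a higher number that more compound is needed for the effect. Compound 3 therefore has no exact position in the series, only its limit of > 50 mg/kg.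

Compound 4 `CCC(=O)N(c1ccc(C#N)cc1)C1CCCC1N(C)C` differs from compound 3 in one group: cyano in place of methoxycarbonyl on an aromatic carbon. Three measured steps change a group on an aromatic carbon: a step that the two limits leave unreadable from compound 1 to compound 2, a step that the two limits leave unreadable from compound 1 to compound 3 and a step that the two limits leave unreadable from compound 2 to compound 3. None of them has a readable size, and none shows a direction. The expectation for compound 4 rests on compound 3 and the other two measured compounds: the limit of > 50 mg/kg in this assay, at which 3 of the 3 values shown sit. The estimate is a step that the limit leaves unreadable from compound 3 to compound 4, with no step beyond the scatter expected in either direction. Compound 4 is expected at 70 mg/kg, within an estimated range from 30 mg/kg to 200 mg/kg.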

Compound 4, dose for half-maximal effect: > 50 mg/kg
Compound 4 gave a limit, no number; the forecaster's own chance of this, stated with the estimate: 75%; the middle value does not contradict the limit.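

Compound 4 adds no readable step to compound 1, compound 2 or compound 3, because all four compounds give only a limit and no number: the limit of > 50 mg/kg in this assay, at which 4 of the 4 values shown sit.

The compounds shown leave open what dose of any of them gives the half-maximal effect in this assay, and whether chloro, fluoro, methoxycarbonyl or cyano makes any difference to it.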